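Aryl replacement on the five-membered core of compound 2

A few compounds are considered here, and "the series" means these few. Any claim that something is new, unique, unknown or untested is made for them only; others in the source may bear on it.

Two compounds share the core and differ only in the aryl group on it. Compound 1 `COc1cc(-n2c(-c3ccc(Br)cc3)cn(C(C)=O)c2=O)cc(OC)c1OC` in a functional assay on K-562R cells (Homo sapiens) for cytotoxicity, read by MTT assay, with a stated time of 48 h (a lower number here means a stronger inhibitor, a higher number a weaker inhibitor), gives 900 nM. Among the measured compounds shown here, compound 2 `COc1cc(-n2c(-c3ccc([N+](=O)[O-])cc3)cn(C(C)=O)c2=O)cc(OC)c1OC` in this assay gives 49600 nM, the highest of the two numbers, and the step of a 55-fold higher number from compound 1 to compound 2 (1.74 log units; beyond the scatter) is the only measured step. Compound 3 `COc1ccc(-c2cn(C(C)=O)c(=O)n2-c2cc(OC)c(OC)c(OC)c2)cc1OC` carries the change (3,4-dimethoxyphenyl in place of 4-nitrophenyl on an aromatic carbon). For the measured compounds named here, no measured step covers this exact exchange; the one step that bears on it shows that replacing bromo with nitro at the same aromatic carbon raised the number strongly, so removal of the 4-nitrophenyl in favour of another aryl is expected to lower the number, though how far the 3,4-dimethoxyphenyl resembles the bromophenyl of compound 1 is unknown. Compound 3 is therefore expected to show the step of a 17-fold lower number from compound 2 to compound 3 (1.22 log units; beyond the scatter) in this assay. The estimate for compound 3 is 3000 nM, with a range from 600 nM to 15000 nM.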

Compound 3, half-maximal inhibitory concentration: > 50000 nM
Compound 3 gave a limit, no number; the forecaster's own chance of this, stated with the estimate: 5%; middle value at least 16-fold (1.22 log units) from the limit.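

Compound 3 gives a limit of the assay, not a number: the limit of > 50000 nM in this assay, at which 1 of the 3 values shown sits. Replacing 4-bromophenyl with 3,4-dimethoxyphenyl on this aromatic carbon gives an at least 55-fold higher number from compound 1 to compound 3 (1.74 log units; beyond the scatter) in this assay, so a second replacement of the 4-bromophenyl of compound 1 also ends far up the scale, and the high number of compound 2 is no longer unique to 4-nitrophenyl. Replacing 4-nitrophenyl with 3,4-dimethoxyphenyl gives a number no lower from compound 2 to compound 3 (the limit leaves the size open), so these two aryl groups cannot be ranked against each other, and among the three aryl groups shown only 4-bromophenyl gives a number well inside the range of the assay.

Open, from the compounds shown here alone, is whether the number of compound 1 depends on bromo itself, or whether 4-chlorophenyl or unsubstituted phenyl would stand near it. Going by these compounds, how an amine on this aryl ring would read also remains open.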